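A few compounds are considered here, and "the series" means these few. Any claim that something is new, unique, unknown or untested is made for them only; others in the source may bear on it.

Measured compounds:
Compound 1 `Nc1ccccc1NC(=O)c1ccc(CSC(=S)N2CCN(Cc3ccncc3)CC2)cc1`: in a functional assay on A-375 cells (Homo sapiens) for antiproliferative activity, read by CCK-8 assay, with a stated time of 72 h, tested at 2 uM (on this read-out lower numbers stand for a weaker effect and higher numbers for a stronger effect at the one concentration tested), compound 1 gives 33.1%.
Compound 2 `CN1CCN(C(=S)SCc2ccc(C(=O)Nc3ccccc3N)cc2)CC1`: in this assay compound 2 gives 36.6%.
Compound 3 `Cc1ccc(N2CCN(C(=S)SCc3ccc(C(=O)Nc4ccccc4N)cc3)CC2)cc1`: in this assay compound 3 gives 25.8%.

Compound 3 has the lowest of the three numbers. Among the measured compounds shown here, its distance from compound 1 is small, a number 7.3 percentage points lower from compound 1 to compound 3 (within the scatter), so the two cannot be ordered; its distance from compound 2 is larger, a number 10.8 percentage points lower from compound 2 to compound 3 (beyond the scatter), the only step here that exceeds the scatter.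

Compound 4 `Nc1ccccc1NC(=O)c1ccc(CSC(=S)N2CCN(c3ccccc3)CC2)cc1` differs from compound 3 by hydrogen in place of methyl on an aromatic carbon, at an aromatic carbon of the six-membered ring of carbon only. For the measured compounds named here, none of the measured steps touches this ring: a number 3.5 percentage points higher from compound 1 to compound 2 (within the scatter) and a number 7.3 percentage points lower from compound 1 to compound 3 (within the scatter) exchange whole groups on the ring amine nitrogen, and a number 10.8 percentage points lower from compound 2 to compound 3 (beyond the scatter) replaces methyl with 4-methylphenyl on that nitrogen. All three steps are small, and the present change removes a single carbon. In this assay no step beyond the scatter is therefore anticipated.

Compound 4 is expected to give 27%, in the range 14% to 40%, a step of a number 1.2 percentage points higher from compound 3 to compound 4 (within the scatter) expected to stay within the scatter.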

Compound 4, a percentage reported as inhibition, at one concentration (the size of the read-out at that concentration, not a potency): 27.5%
Compound 4: middle estimate off by 0.5 percentage points, on the low side; low and high end bracket the measured number.
By their numbers in this assay, from the lowest: compounds 3, 4, 1 and 2 (each within the scatter of the next, the first and the last beyond it).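

In this assay, taking the methyl off the aromatic carbon para to a large group gives a number 1.7 percentage points higher from compound 3 to compound 4 (within the scatter), so at this position hydrogen and methyl cannot be told apart. Among the compounds shown here, with the bare phenyl on the ring amine nitrogen, the comparisons read a number 9.1 percentage points lower from compound 2 to compound 4 (within the scatter) and a number 5.6 percentage points lower from compound 1 to compound 4 (within the scatter), so the only step beyond the scatter, a number 10.8 percentage points lower from compound 2 to compound 3 (beyond the scatter), has no counterpart beyond the scatter once this methyl is gone, although the two steps to compound 2 are close in size and this should not be read as a real effect of the methyl. No available evidence bears on the reasons for these numbers.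

On these data alone, it remains open whether a methoxy group, a chlorine or a carboxylic acid on the same aromatic carbon would shift the read-out beyond the scatter. As far as these compounds go, it also remains open how a free amine hydrogen in place of the aryl group on the ring nitrogen would compare.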